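Swapping iodo for trifluoromethyl on the sulfonyl-bearing ring

A few compounds are considered here, and "the series" means these few. Any claim that something is new, unique, unknown or untested is made for them only; others in the source may bear on it.

Compound 1, `COc1ccc(C(=O)N2CCN(c3nc(N)c4cc(OC)c(OC)cc4n3)CC2)cc1OC`, gives 71000 nM in a functional assay on PC-3 cells (Homo sapiens) for inhibition; on this read-out lower numbers stand for stronger inhibition and higher numbers for weaker inhibition.
Compound 2, `COc1cc2nc(N3CCN(S(=O)(=O)c4ccc(I)cc4)CC3)nc(N)c2cc1OC`, gives 15000 nM in this assay.
Compound 3, `COc1cc2nc(N3CCN(S(=O)(=O)c4ccc([N+](=O)[O-])cc4)CC3)nc(N)c2cc1OC`, gives 36000 nM in this assay.

Compound 2 stands lowest of the three numbers, so it is the strongest inhibitor measured here; compound 3 is the nearest and compound 1 the furthest from it. Compound 4, `COc1cc2nc(N3CCN(S(=O)(=O)c4ccc(C(F)(F)F)cc4)CC3)nc(N)c2cc1OC`, has not yet been measured. It differs from compound 2 in one place: trifluoromethyl in place of iodo on an aromatic carbon. Within the data shown here, only one measured step touches this position: a 2.4-fold higher number from compound 2 to compound 3 (0.38 log units; beyond the scatter). That step shows the number shifting modestly when the iodo group is exchanged. Compound 1 differs from compound 2 elsewhere, so its value says nothing about this position. Among the measured compounds shown here, no measured compound carries a trifluoromethyl group, so the direction is uncertain; a small step, at most a modest weakening like that seen for compound 3, is expected. Compound 4 is therefore expected to give 22000 nM, within 10000 nM to 50000 nM. That estimate corresponds to an expected 1.5-fold higher number from compound 2 to compound 4 (0.17 log units; within the scatter).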

Compound 4, half-maximal inhibitory concentration: 27000 nM
Compound 4: the middle estimate sits 1.2-fold (0.09 log units) below what was measured; the measured number falls inside the stated range.
By their numbers in this assay, from the lowest: compounds 2, 4, 3 and 1 (each within the scatter of the next, the first and the last beyond it).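

In this assay, trifluoromethyl in place of iodo gives a 1.8-fold higher number from compound 2 to compound 4 (0.26 log units; within the scatter), and trifluoromethyl in place of nitro gives a 1.3-fold lower number from compound 3 to compound 4 (0.12 log units; within the scatter). This position therefore accepts trifluoromethyl, with 4 heavy atoms against 1 for iodo, without a shift beyond the scatter, and trifluoromethyl cannot be ranked against either iodo or nitro, even though iodo and nitro themselves differ beyond the scatter. Nothing measured here accounts for these readings.

Whether an amine or a carboxylic acid on this same aromatic carbon would stay within the scatter of these compounds remains open. So does whether a longer chain there would be accepted as trifluoromethyl is, since all three groups compared at this position are single small substituents.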